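Thioamide for nitrile on compound 1: KB-cell inhibition

The compounds below may be only part of what the source reports. "The series", "measured", "known", "first", "only" and "open" are said of these compounds alone.

Measured so far:
compound 1 `N#Cc1cn([C@H]2C[C@H](O)[C@@H](CO)O2)c2ncnc(N)c12` — 25000 nM
compound 2 `N#Cc1cn(C2CCC(CO)O2)c2ncnc(N)c12` — 88000 nM
compound 3 `N#Cc1cn([C@@H]2O[C@H](CO)[C@@H](O)[C@@H]2N)c2ncnc(N)c12` — 105000 nM

In a functional assay on KB cells (Homo sapiens) for inhibition (a higher number here means a weaker inhibitor, a lower number a stronger inhibitor), compound 1 gives 25000 nM, the lowest of the three numbers, while compound 2 gives 88000 nM and compound 3 gives 105000 nM. Within the data shown here, the one single-point step available, a 4.2-fold higher number from compound 1 to compound 3 (0.62 log units; beyond the scatter), concerns a saturated ring carbon and does not bear on the change at hand. Compound 4 `NC(=S)c1cn([C@H]2C[C@H](O)[C@@H](CO)O2)c2ncnc(N)c12` differs from compound 1 by a group of 3 heavy atoms (1 carbon, 1 nitrogen, 1 sulfur; no ring) in place of a group of 2 heavy atoms (1 carbon, 1 nitrogen; no ring), on an aromatic carbon. Among the measured compounds shown here, no measured step touches this position, so the series gives no direction for it. A step within the scatter is therefore expected, a 1.3-fold lower number from compound 1 to compound 4 (0.10 log units; within the scatter). Compound 4 is estimated at 20000 nM, with a range of 5000 nM to 80000 nM.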

Compound 4, half-maximal inhibitory concentration: 7000 nM
For compound 4 the middle estimate is 2.9-fold (0.46 log units) above the measured one; low and high end bracket the measured number.
By their numbers in this assay, from the lowest: compound 4; then compound 1; then compounds 2 and 3 (each within the scatter of the next).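

Replacing the cyano group of compound 1 with the thioamide on this aromatic carbon gives a 3.6-fold lower number from compound 1 to compound 4 (0.55 log units; beyond the scatter) in this assay. This position of the shared core therefore responds to substitution, and a larger group with a hydrogen-bond donor is tolerated here. No evidence on the origin of this step is available.

Going by these compounds, whether the sulfur is needed remains open, as the primary amide, with oxygen in place of sulfur, or a carboxylic acid on this carbon would show. Also open, on these data alone, is whether the thioamide gives a similar step on the cores of compound 2 and compound 3.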